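Swapping Bromo for Fluoro in a Cytotoxicity Series

The compounds below may be only part of what the source reports. "The series", "measured", "known", "first", "only" and "open" are said of these compounds alone.

In a functional assay on PC-3 cells (Homo sapiens) for cytotoxicity, read by MTT assay, with a stated time of 72 h (on this read-out lower numbers stand for stronger inhibition and higher numbers for weaker inhibition), compound 1 (`CNC(=O)c1cc(Oc2ccc(C(=O)/C=C/c3ccc(OC)c(OC)c3OC)cc2)ccn1`) is recorded as "not determined" (no result reported) and carries no number. Among the measured compounds shown here, compound 2 (`CNC(=O)c1cc(Oc2ccc(C(=O)/C=C/c3ccc(Br)cc3)cc2)ccn1`) gives 18500 nM as the only number in hand, so there is no measured compound to rank it against. Compound 3 (`CNC(=O)c1cc(Oc2ccc(C(=O)/C=C/c3ccc(F)cc3)cc2)ccn1`) has not yet been measured. Its structure departs from compound 2 by fluoro in place of bromo on an aromatic carbon in one place: fluoro in place of bromo on an aromatic carbon, para to a large group. For the measured compounds named here, no measured step exists to size this change in this assay here, so the expectation rests on compound 2 alone. The expected step of a 1.2-fold higher number from compound 2 to compound 3 (0.08 log units; within the scatter) is small and within the usual scatter, leaning if anything toward weaker inhibition. For compound 3 the estimated value is 22000 nM with an expected range from 10000 nM to 50000 nM around it.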

Compound 3, half-maximal inhibitory concentration: 6140 nM
The estimate for compound 3 lay 3.6-fold (0.55 log units) above the measured number, and the stated range ends above it.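

In this assay, the group on this aromatic carbon, para to a large group, proves able to move the read-out: fluoro in place of bromo gives a 3.0-fold lower number from compound 2 to compound 3 (0.48 log units; beyond the scatter), a modest step toward stronger inhibition that lies beyond the usual scatter. Among the compounds shown here, this is the first step that can be sized, since the earlier compounds offered only one number and no comparison. The change replaces one heavy atom with another, with no ring, hydrogen-bond donor, hydrogen-bond acceptor or net charge entering or leaving, and nothing available explains the shift.

The compounds shown leave open whether chloro, an amine or a carboxylic acid on the same carbon would match, exceed or lose this gain. They also leave open whether the step would hold with other groups on the shared core.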